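Adding a Larger Group to the Halogenated Ring

The compounds below may be only part of what the source reports. "The series", "measured", "known", "first", "only" and "open" are said of these compounds alone.

Measured so far, in a functional assay on the whole organism for inhibition, with Scenedesmus acutus as the target; a lower number here means a stronger inhibitor, a higher number a weaker inhibitor:
compound 1, `S=c1n(-c2ccc(Cl)cc2)c(=S)n2n1CCCC2`, 61.7 nM
compound 2, `Fc1cc(Cl)ccc1-n1c(=S)n2n(c1=S)CCCC2`, 23.4 nM
compound 3, `Cc1cc(Cl)ccc1/N=c1\sc(=S)n2n1CCCC2`, 457 nM

Compound 2 gives the lowest number of the three in this assay. For the measured compounds named here, its nearest neighbour is compound 1, and the only measured step between compounds differing in one place is a 2.6-fold lower number from compound 1 to compound 2 (0.42 log units; beyond the scatter). Compound 3 differs from compound 2 in more than one place, so only its values can be set side by side: compound 3 gives a much higher number than compound 2.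

The next compound, compound 4, is `COC(=O)CSc1cc(-n2c(=S)n3n(c2=S)CCCC3)c(F)cc1Cl`. It differs from compound 2 by one change: ((methoxycarbonyl)methyl)sulfanyl in place of hydrogen on an aromatic carbon

Going by the values given here, no measured step involves a group of this kind, so the step from compound 1 to compound 2 gives only a rough sense of how much a single substitution on this ring can shift this assay, and in which direction a larger group will move the number remains open. For compound 4 the expected value in this assay is 60 nM, with a range from 15 nM to 250 nM. This estimate implies a step of a 2.6-fold higher number from compound 2 to compound 4 (0.41 log units; beyond the scatter), expected to remain modest.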

Compound 4, half-maximal inhibitory concentration: 186 nM
Compound 4: the middle estimate sits 3.1-fold (0.49 log units) below what was measured, and the stated range covers the measured number.
By their numbers in this assay, from the lowest: compound 2; then compound 1; then compound 4; then compound 3.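

In this assay, ((methoxycarbonyl)methyl)sulfanyl on the aromatic carbon ortho to the chloro group and para to the fluoro group brings a 7.9-fold higher number from compound 2 to compound 4 (0.90 log units; beyond the scatter) and so costs inhibition at this position of the ring. The earlier step, a 2.6-fold lower number from compound 1 to compound 2 (0.42 log units; beyond the scatter) with the addition of a fluoro group, ran the opposite way, so a single substitution on this ring can move the number in either direction, depending on the group and its place. Nothing available here explains why the number rises.

From the compounds shown here alone, whether a smaller group on this carbon, such as methylsulfanyl, or a carboxylic acid in place of the methyl ester would bring the number back towards that of compound 2 remains open. So does the effect of an amine on the same carbon.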